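Swapping the Ring on the Amine Nitrogen

The compounds below may be only part of what the source reports. "The series", "measured", "known", "first", "only" and "open" are said of these compounds alone.

Measured compounds:
Compound 1, `CC(C)N1CCN(Cc2csc(N)c2C(=O)c2ccc(Cl)cc2)CC1`: 7.3%
Compound 2, `Nc1scc(CN2CCN(c3ccncc3)CC2)c1C(=O)c1ccc(Cl)cc1`: -8.3%

In a functional assay on CHO cells with adenosine receptor A1 (Homo sapiens) as the target, read by cAMP accumulation and immunoassay, with a stated time of 6 min, tested at 1 uM (a higher number here means a weaker effect of the compound at the concentration tested, a lower number a stronger effect), compound 1 gives 7.3%, and compound 2 gives -8.3%. Among the measured compounds shown here, compound 2 stands lowest of the two numbers; its nearest neighbour is compound 1, and the single measured step, a number 15.6 percentage points lower from compound 1 to compound 2 (beyond the scatter), lies beyond the scatter but is modest in size. Both numbers sit near zero, so neither compound shows much effect at the concentration tested.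

Compound 3, `Nc1scc(CN2CCN(c3cc(F)cc(F)c3)CC2)c1C(=O)c1ccc(Cl)cc1`, has not been measured in this assay. It differs from compound 2 in one place: 3,5-difluorophenyl in place of pyridin-4-yl on an amine nitrogen in a ring. For the measured compounds named here, no measured step covers a change of this kind; the only step known, from compound 1 to compound 2, swaps a different pair of groups on the same amine nitrogen in a ring and moved the number only modestly. With two near-zero values and nothing pointing up or down, compound 3 is expected to stay in the same low region, with a step of a number 8.3 percentage points higher from compound 2 to compound 3 (within the scatter) that is not expected to exceed the scatter. The estimate for compound 3 is therefore 0%, with a range from -15% to 15%.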

Compound 3, a percentage reported as activity, at one concentration (the size of the read-out at that concentration, not a potency): -66%
Estimate against measurement, compound 3: 66 percentage points above; the measured number lies below the stated range.
By their numbers in this assay, from the lowest: compound 3; then compound 2; then compound 1.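

In this assay, the group on the amine nitrogen in a ring proves able to move the number much further than the earlier pair suggested, with a number 57.7 percentage points lower from compound 2 to compound 3 (beyond the scatter) marking a large change toward a stronger effect at the concentration tested. Both groups in this swap are six-membered aromatic rings, so having an aromatic ring at this position does not by itself give the stronger effect: pyridin-4-yl differs only modestly from isopropyl, while 3,5-difluorophenyl stands well apart, and a number 73.3 percentage points lower from compound 1 to compound 3 (beyond the scatter) shows a large change from the isopropyl compound as well. Nothing available explains why the number falls so far at this position.

The swap removes the ring nitrogen and adds the fluorines in one move, so the compounds shown cannot say which of these changes carries the step, and an unsubstituted phenyl ring would help to separate them. Going by these compounds, it also remains open whether the fluorines are specifically needed, or whether chlorine atoms or methoxy groups on the same ring would give a similar number.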